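Fluoro for methyl on the pendant ring: a small step expected

This account rests on a few compounds, and the source may have more. Where it says the series, first, only, none or still open, it means among the compounds named here.

Measured so far:
Compound 1, `Cc1ccc(-c2ccc(F)cc2)n1-c1ccc(-c2nc3ccc(F)cc3s2)cc1`: 1790 nM
Compound 2, `COc1ccc2nc(-c3ccc(-n4c(C)ccc4-c4ccc(C)cc4)cc3)sc2c1`: 2570 nM

Both compounds share a core and were tested in a functional assay on MCF7 cells (Homo sapiens) for cytotoxicity, read by sulforhodamine B assay, with a stated time of 48 h; a lower number here means a stronger inhibitor of growth, a higher number a weaker inhibitor of growth. Compound 2 holds the higher of the two numbers, yet compound 1 sits close by, and the gap between them lies within the usual scatter, so the two cannot be ranked against each other. Compound 3, `COc1ccc2nc(-c3ccc(-n4c(C)ccc4-c4ccc(F)cc4)cc3)sc2c1`, has not yet been measured in this assay. It differs from compound 2 in one place: fluoro in place of methyl on an aromatic carbon. Among the compounds with values here, compound 1 carries the same fluoro group on its pendant ring, but since it also differs elsewhere, no single step from it can be read off. Within the data shown here, with no step between measured compounds to lean on, the change from compound 2 to compound 3 is expected to move the number little, if at all, beyond the scatter, in no clear direction: a 1.2-fold lower number from compound 2 to compound 3 (0.07 log units; within the scatter). Compound 3 is therefore estimated at 2200 nM, within a range of 900 nM to 5500 nM.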

Compound 3, concentration for 50% growth inhibition: 2480 nM
Beside the measured number, compound 3's estimate is 1.1-fold (0.05 log units) below it; measured number inside the range.
By their numbers in this assay, from the lowest: compounds 1, 3 and 2 (each within the scatter of the next).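

In this assay, swapping 4-methylphenyl for 4-fluorophenyl gives a 1.0-fold lower number from compound 2 to compound 3 (0.02 log units; within the scatter), so at this spot, para to a large group, the two groups cannot be told apart. A second comparison that differs in one place, at another site on the shared core, gives a 1.4-fold higher number from compound 1 to compound 3 (0.14 log units; within the scatter), so methoxy and fluoro at that site cannot be told apart in this assay either. Nothing measured here offers an explanation for either result.

As far as these compounds go, only small groups have been compared at these two sites, so it remains open whether any group at either one can move the number beyond the scatter. An amine, a carboxylic acid or a longer chain such as butyl at the pendant ring position would be a much larger test of this.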